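Bromo in place of nitro on the sulfonyl ring

The compounds below may be only part of what the source reports. "The series", "measured", "known", "first", "only" and "open" are said of these compounds alone.

Measured so far:
- compound 1, `COc1ccc(-c2c(Cl)c(=O)c3c(OC)cc(OC)cc3n2S(=O)(=O)c2ccc(OC)cc2)cc1`: 17900 nM
- compound 2, `COC(=O)c1cc(=O)c2cc(N)ccc2[nH]1`: > 67200 nM
- compound 3, `COc1ccc(-c2cc(=O)c3c(OC)cc(OC)cc3n2S(=O)(=O)c2ccc([N+](=O)[O-])cc2)cc1`: 17100 nM

All three were tested in a functional assay on SUP-B15 cells (Homo sapiens) for antiproliferative activity, with a stated time of 72 h; a higher number here means that more compound is needed for the effect, a lower number that less compound is needed. For compound 2 the value > 67200 nM is a limit of the assay and not a number; it is the limit of > 67200 nM in this assay, at which 1 of the 3 values shown sits. Of the two numbers, compound 3 gives one and compound 1 gives the other, and the two sit within the usual scatter of each other, so nothing separates them.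

Compound 4, `COc1ccc(-c2cc(=O)c3c(OC)cc(OC)cc3n2S(=O)(=O)c2ccc(Br)cc2)cc1`, has not yet been measured. It differs from compound 3 in one place: bromo in place of nitro on an aromatic carbon. Among the measured compounds shown here, no step between two measured compounds is available for this change. A step of no size beyond the scatter is expected in this assay, since compound 1, carrying another group on its sulfonyl ring, gives 17900 nM close to compound 3. Compound 4 is therefore estimated at 17000 nM, expected between 6000 nM and 50000 nM. That estimate means an expected step of a 1.0-fold lower number from compound 3 to compound 4 (0.00 log units; within the scatter), within the scatter.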

Compound 4, half-maximal effective concentration: 63800 nM
Compound 4: middle estimate off by 3.8-fold (0.57 log units), on the low side, outside the stated range (above it).
By their numbers in this assay, from the lowest: compounds 3 and 1 (each within the scatter of the next); then compound 4. At a limit, above all of these: compound 2.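

In this assay the group on the sulfonyl ring does matter: the change from 4-nitrophenyl to 4-bromophenyl gives a 3.7-fold higher number from compound 3 to compound 4 (0.57 log units; beyond the scatter) as a modest step beyond the scatter. Among the compounds shown here, this is the first step between two measured compounds that differ in one place, something compound 1 could not offer, as it differs from compound 3 in more than one place. Compound 2 gives a limit of the assay and not a number: the limit of > 67200 nM in this assay, at which 1 of the 4 values shown sits.

On these data alone, whether this step comes from losing the nitro group or from bringing in the bromo group stays open, as a single pair cannot separate the two. Also open, as far as these compounds go, is where other groups at this place, such as an amine or a carboxylic acid, would fall in this assay.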